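Ring-nitrogen substituent change in an antiproliferative series

The source may hold more compounds than are shown below. What is called first, only, known or untested is meant among the compounds shown, and "the series" means these compounds.

Measured so far:
compound 1, `N#Cc1ccc(N2CCN(C(=S)SCc3ccc(C(=O)Nc4ccccc4N)cc3)CC2)cc1`: 41.4%
compound 2, `Cc1ccc(N2CCN(C(=S)SCc3ccc(C(=O)Nc4ccccc4N)cc3)CC2)cc1`: 25.8%

In a functional assay on A-375 cells (Homo sapiens) for antiproliferative activity, read by CCK-8 assay, with a stated time of 72 h, tested at 2 uM (on this read-out lower numbers stand for a weaker effect and higher numbers for a stronger effect at the one concentration tested), compound 1 gives 41.4% and compound 2 gives 25.8%. Going by the values given here, compound 2 thus stands lowest of the two numbers; the only measured step, a number 15.6 percentage points lower from compound 1 to compound 2 (beyond the scatter), is modest but beyond the scatter.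

Compound 3, `CN1CCN(C(=S)SCc2ccc(C(=O)Nc3ccccc3N)cc2)CC1`, differs from compound 2 by methyl in place of 4-methylphenyl on an amine nitrogen in a ring. Among the compounds with values here, no measured step bears on this change directly: the single known step alters a group on the aromatic ring that now leaves, rather than removing that ring. Neither measured value is a high one, and nothing indicates that removing the ring raises the number. The step of a number 3.8 percentage points lower from compound 2 to compound 3 (within the scatter) is therefore expected to be small and within the scatter, with a wide uncertainty. Compound 3 is estimated at 22%, in the range 6% to 40%.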

Compound 3, a percentage reported as inhibition, at one concentration (the size of the read-out at that concentration, not a potency): 36.6%
Beside the measured number, compound 3's estimate is 14.6 percentage points below it, within the range that was stated.
By their numbers in this assay, from the lowest: compound 2; then compounds 3 and 1 (each within the scatter of the next).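

Methyl in place of 4-methylphenyl on this amine nitrogen gives, in this assay, a number 10.8 percentage points higher from compound 2 to compound 3 (beyond the scatter), so an aromatic ring at this position is not needed to keep the number in this pair. Methyl in place of 4-cyanophenyl gives a number 4.8 percentage points lower from compound 1 to compound 3 (within the scatter), so of the two aryl groups only 4-methylphenyl is separated from methyl by more than the scatter. No measurement here explains either step.

From the compounds shown here alone, whether a longer chain such as butyl, a benzyl group or a plain hydrogen on this ring nitrogen would hold or shift the number remains open. Going by these compounds, with one concentration per compound, the potency of all three compounds also remains open.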